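The source may hold more compounds than are shown below. What is called first, only, known or untested is meant among the compounds shown, and "the series" means these compounds.

Measured so far in a functional assay on Urethra with Alpha-1A adrenergic receptor (Oryctolagus cuniculus) as the target; on this read-out lower numbers stand for smaller maximal responses and higher numbers for larger maximal responses:
compound 1 `O=S(=O)(Nc1cccc2c1CCCC2c1c[nH]cn1)C1CC1` – 51%;
compound 2 `CS(=O)(=O)Nc1cccc2c1CCC=C2c1c[nH]cn1` – 57%; 23% (2 entries);
compound 3 `CCS(=O)(=O)Nc1cccc2c1CCC2c1c[nH]cn1` – 87%.

Compound 1 stands at the lower of the two single numbers in this assay; compound 3 sits well above it, beyond the usual scatter. Compound 2 gives no single number, as its two entries fall far apart (the several entries of compound 2 in this assay, 57%; 23% (2 entries)). The piece now turns to compound 4 `CC(C)S(=O)(=O)Nc1cccc2c1CCCC2c1c[nH]cn1`, which has not yet been measured. Compound 4 differs from compound 1 in one place: isopropyl in place of cyclopropyl on a sulfonyl sulfur. For the measured compounds named here, no measured pair shows the effect of this change, so only a guess can be made. A step of little size from compound 1 to compound 4 is expected, likely within the scatter, and the expected step is a number 7 percentage points higher from compound 1 to compound 4 (within the scatter). Compound 4 is thus estimated to reach 58%, with a range from 35% to 85%.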

Compound 4, largest response reached (reported as efficacy), in percent of the reference or control that the assay uses: 74%
Compound 4: the middle estimate sits 16 percentage points below what was measured; the measured number falls inside the stated range.
By their numbers in this assay, from the lowest: compound 1; then compound 4; then compound 3.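

The sulfonyl sulfur proves sensitive to a small swap. In this assay, the step is a number 23 percentage points higher from compound 1 to compound 4 (beyond the scatter). Cyclopropyl and isopropyl have the same count of carbons, so opening the ring alone gives a change beyond the scatter, and nothing measured here explains this step.

On these data alone, what a phenyl group or a longer chain on the sulfonyl sulfur would give remains open. Also open, as far as these compounds go, is whether this step holds on other cores: compound 2 and compound 3 each differ from compound 1 in more than one place.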